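A few compounds are considered here, and "the series" means these few. Any claim that something is new, unique, unknown or untested is made for them only; others in the source may bear on it.

The series centres on two acetylated nucleoside analogues that share a bicyclic core. Compound 1, `CCCCCc1ccc(-c2oc3nc(=O)n([C@H]4C[C@H](OC(C)=O)[C@@H](COC(C)=O)O4)cc3c2C#CCCO)cc1`, carries a hydroxy at the end of its alkynyl chain, and in an ADME assay on HEL cells (Homo sapiens) for cytotoxicity, read by cell counting, with a stated time of 3 days (a lower number here means that less compound is tolerated, a higher number that more compound is tolerated), compound 1 gives 100000 nM. Compound 2, `CC(=O)OC[C@H]1O[C@@H](n2cc3c(C#CCCN4C(=O)c5ccccc5C4=O)c(-c4ccc(C)cc4)oc3nc2=O)C[C@@H]1OC(C)=O`, differs in the aryl substituent and in the group at the end of the chain, and in this assay compound 2 gives 100000 nM. Compound 2 therefore stands level with compound 1 at the digits shown, the two values lying within the scatter of each other, so no order between them can be read.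

The step under consideration leads from compound 2 to compound 3, `CC(=O)OC[C@H]1O[C@@H](n2cc3c(C#CCCO)c(-c4ccc(C)cc4)oc3nc2=O)C[C@@H]1OC(C)=O`, which is not yet measured. The change is one oxygen atom in place of a group of 11 heavy atoms (8 carbon, 1 nitrogen, 2 oxygen; one five-membered non-aromatic ring with 1 hetero atom, one six-membered aromatic ring of carbon only), on a saturated chain carbon, two bonds along the chain from a triple-bonded carbon. The group that leaves is the larger one, the hydroxy that enters being a single oxygen atom on the saturated chain carbon two bonds along the chain from the triple-bonded carbon.

Since compounds 1 and 2 sit level despite differing at this very chain end, the step of no change at the digits printed from compound 2 to compound 3 (within the scatter) is expected to be none beyond the scatter. Compound 3 is accordingly estimated at 100000 nM, with a range from 50000 nM to 100000 nM.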

Compound 3, minimum cytotoxic concentration: > 100000 nM
Compound 3 ended at the assay's limit; the forecaster's own chance of this, stated with the estimate: 40%; the middle value sits exactly at the limit.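

In this assay compound 3 gives > 100000 nM, which is a limit of the assay and not a number. The hydroxy on the saturated chain carbon, in place of the group of 11 heavy atoms, thus brings a number no lower from compound 2 to compound 3 (the limit leaves the size open) and the same holds for hydrogen in place of butyl on the saturated chain carbon bound to an aromatic carbon, which brings a number no lower from compound 1 to compound 3 (the limit leaves the size open) in the same way. Neither of these two changes can be given a size, because the value of compound 3 stands at a limit: the limit of > 100000 nM in this assay, at which 1 of the 3 values shown sits.

The compounds shown therefore leave open how far either change raises the number, if it raises it at all. They also leave open whether an amine or a carboxylic acid in place of the hydroxy at the chain end, or a longer chain, would bring a value that can be read within the range of the assay.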